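This account rests on a few compounds, and the source may have more. Where it says the series, first, only, none or still open, it means among the compounds named here.

Measured compounds:
Compound 1 `COc1ccc(CNc2nc3cc(N)cc(N)c3nc2-c2ccccc2)cc1OC` gives 79400 nM in a functional assay on BT-549 cells (Homo sapiens) for inhibition, read by sulforhodamine B assay, with a stated time of 48 h; on this read-out lower numbers stand for higher toxicity in this test and higher numbers for lower toxicity in this test.
Compound 2 `CCOC(=O)[C@H](CCC(=O)O)NC(=O)c1ccc(Sc2nc3cc(N)cc(N)c3nc2-c2ccccc2)cc1` gives only a limit of < 100000 nM in this assay.

Within the data shown here, compound 1 stands as the only compound of the two with an actual number in this assay; the other value shown is a limit, and the evidence on this point is the limit of < 100000 nM in this assay, at which 1 of the 2 values shown sits. Compound 2 is therefore known only through the limit that its measurement reports, and its sentence says nothing more than that.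

Compound 3 `COc1cc(CNc2nc3cc(N)cc(N)c3nc2-c2ccccc2)cc(OC)c1OC` is not yet measured. It differs from compound 1 by methoxy in place of hydrogen on an aromatic carbon, so the change is a methoxy in place of hydrogen on an aromatic carbon, ortho to a methoxy group and meta to a methoxy group and to a large group on the same ring. No step between measured compounds is known, and nothing shown points to a change that would leave the usual scatter. Compound 3 is expected to give about 70000 nM in this assay, with a range from 30000 nM to 160000 nM. The estimated step from compound 1 is a 1.1-fold lower number from compound 1 to compound 3 (0.05 log units; within the scatter), a step expected to stay within the scatter and to show no clear direction.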

Compound 3, concentration lethal to 50% of the cells: 27500 nM
Beside the measured number, compound 3's estimate is 2.5-fold (0.41 log units) above it; measured number below the stated range.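

In this assay, methoxy in place of hydrogen on an aromatic carbon, ortho to a methoxy group and meta to a methoxy group and to a large group, gives a 2.9-fold lower number from compound 1 to compound 3 (0.46 log units; beyond the scatter). Among these compounds, this is the first step that can be read, and it shows that this position on the ring is not silent: one added methoxy moves the read-out modestly towards higher toxicity in this test, which the earlier compounds, with no step between them, could not show. Nothing shown bears on why the number moves with this change.

From the compounds shown here alone, it stays open whether the step belongs to methoxy itself or would also appear with another group at the same place, such as a hydroxyl, a fluorine, an amine, a carboxylic acid or a longer chain like ethoxy. Going by these compounds, it also stays open whether the same change would move the number on a different core, since this single step rests on one pair of compounds in one cell line.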